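Trimming the Amide Side Chain Down to Acetyl

A few compounds are considered here, and "the series" means these few. Any claim that something is new, unique, unknown or untested is made for them only; others in the source may bear on it.

Compound 3 `C[C@@H]1C[C@H]1C(=O)N1CC2CNCC2C1` is one of three close relatives that share a bicyclic amide core. In an assay on SHEP1 cells for agonist activity at Neuronal acetylcholine receptor; alpha4/beta2 (Homo sapiens), read by FLIPR and calcium flux (a higher number here means that more compound is needed for the effect, a lower number that less compound is needed), compound 3 gives 1700 nM. Compound 2 `C[C@@H]1C[C@@H]1C(=O)N1CC2CNCC2C1` gives 1200 nM, and compound 1 `C[C@H]1C[C@H]1C(=O)N1CC2CNCC2C1` gives 19000 nM. The steps of a 16-fold lower number from compound 1 to compound 2 (1.20 log units; beyond the scatter) and an 11-fold lower number from compound 1 to compound 3 (1.05 log units; beyond the scatter) are large, whereas a 1.4-fold higher number from compound 2 to compound 3 (0.15 log units; within the scatter) is not, so compound 3 stands close to compound 2 and far from compound 1. Compound 4 `CC(=O)N1CC2CNCC2C1` is altered in a different way: methyl in place of 2-methylcyclopropyl on a carbonyl carbon. Going by the values given here, none of the measured steps touches this group; all three concern only the drawn configuration at ring carbons, so they give no guide to the size or direction of this change. Compound 4 is nevertheless expected to need more compound, with an estimated 3.5-fold higher number from compound 3 to compound 4 (0.55 log units; beyond the scatter), giving 6000 nM within a range from 1200 nM to 30000 nM.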

Compound 4, half-maximal effective concentration: 2600 nM
Beside the measured number, compound 4's estimate is 2.3-fold (0.36 log units) above it, and the stated range covers the measured number.
By their numbers in this assay, from the lowest: compounds 2, 3 and 4 (each within the scatter of the next, the first and the last beyond it); then compound 1.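

So the ring is not essential at this place: methyl, with a single carbon, can replace 2-methylcyclopropyl on the carbonyl carbon, giving a 1.5-fold higher number from compound 3 to compound 4 (0.18 log units; within the scatter) and only a modest 2.2-fold higher number from compound 2 to compound 4 (0.34 log units; beyond the scatter). The same replacement gives a 7.3-fold lower number from compound 1 to compound 4 (0.86 log units; beyond the scatter), so the arrangement drawn in compound 1 stands out among these compounds, and the plain acetyl amide does not share its high number. Nothing measured here explains the size of these steps.

As far as these compounds go, it remains open how a longer chain such as ethyl or propyl would behave at this carbonyl carbon. An amine on the side chain is equally uncharted.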